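Solubility of compound 4 judged from three measured analogues

The source may report more compounds than this note shows. Statements on the series, on what has been measured and on what is new or still open speak of the compounds shown alone.

The measure here is a physicochemical assay for solubility, with a stated time of 18 h, at pH 7.4; on this read-out lower numbers stand for lower solubility and higher numbers for higher solubility. Within the data shown here, compound 2 `COc1ccc(F)cc1CNCCCNc1ccnc2cc(Cc3cc(C)cc(C)c3)ccc12` is the reference point: in this assay compound 2 gives 4200 nM, the lowest of the three numbers known. Compound 1 `COc1ccccc1Oc1ccc2c(NCCCNCc3ccco3)ccnc2c1` gives 14500 nM in this assay, and compound 3 `COc1cccc(CNCCCNc2ccnc3cc(Oc4ccc(Cl)cc4)ccc23)c1O` gives 14500 nM; each of these stands above compound 2 by a gap that is beyond the scatter, while compound 1 and compound 3 themselves give the same number. Among the measured compounds shown here, no pair of these three differs in only one place, so no single-change step is available.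

Compound 4 `COc1cccc(Oc2ccc3c(NCCCNCc4cc(F)ccc4OC)ccnc3c2)c1` has not been measured in this assay. It differs from compound 2 by 3-methoxyphenoxy in place of 3,5-dimethylbenzyl on an aromatic carbon. The group that leaves carries no hydrogen-bond acceptors; the group that enters carries two oxygen atoms and two acceptors, and it joins the core through an oxygen, as in compound 1 and compound 3.

Compound 4 is therefore expected to move upward in this assay, because compound 1 gives 14500 nM with an oxygen-linked group at the same place. The expected step of a 2.6-fold higher number from compound 2 to compound 4 (0.42 log units; beyond the scatter) should lie beyond the scatter. Compound 4 is estimated at 11000 nM, with a range from 5000 nM to 24000 nM.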

Compound 4, solubility: 14500 nM
Compound 4: middle estimate off by 1.3-fold (0.12 log units), on the low side; the range from low to high includes it.
By their numbers in this assay, from the lowest: compound 2; then compounds 1, 3 and 4 (each within the scatter of the next).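

In this assay, among these compounds, replacing 3,5-dimethylbenzyl with 3-methoxyphenoxy on an aromatic carbon gives the first single-change step in this set, with a 3.5-fold higher number from compound 2 to compound 4 (0.54 log units; beyond the scatter) as a modest move. The earlier gaps around compound 2 came from compounds that differ in more than one place, so they could not be tied to this position, whereas here a change at this position alone goes with a higher number. The two groups have the same count of heavy atoms and each holds one six-membered aromatic ring of carbon only, so the step comes with a swap that keeps both of those counts while the entering group brings two oxygen atoms and two hydrogen-bond acceptors.

No measured evidence bears on what lies behind this step. Still open, on these data alone, is whether the oxygen link or the methoxy group goes with the higher number, which an unsubstituted phenoxy group would help to separate, and how a group of another kind at this place, such as an amine or a carboxylic acid, would read in this assay.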